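Fluorine count on the benzyl arm and tolerated concentration

The compounds below may be only part of what the source reports. "The series", "measured", "known", "first", "only" and "open" are said of these compounds alone.

In an ADME assay on MT4 cells (Homo sapiens) for cytotoxicity, read by MTT assay (a higher number here means that more compound is tolerated, a lower number that less compound is tolerated), compound 3 `CCOC(=O)/C(O)=C/C(=O)c1cn(Cc2ccccc2F)c2cccc(OC)c12` gives 63300 nM, the second highest of the three numbers shown, though within the scatter of both neighbours: compound 1 `CCOC(=O)/C(O)=C/C(=O)c1cn(Cc2cccc(F)c2)c2cccc(OC)c12` gives 63200 nM and compound 2 `CCOC(=O)/C(O)=C/C(=O)c1cn(Cc2ccc(F)cc2F)c2cccc(OC)c12` gives 65500 nM. Compound 4 `CCOC(=O)/C(O)=C/C(=O)c1cn(Cc2c(F)ccc(F)c2F)c2cccc(OC)c12` carries 2,3,6-trifluorophenyl in place of 2-fluorophenyl on a saturated chain carbon bound to an aromatic nitrogen. Among the compounds with values here, the steps that bear on this change all shifted fluorine on the same ring: a 1.0-fold higher number from compound 1 to compound 2 (0.02 log units; within the scatter), a 1.0-fold higher number from compound 1 to compound 3 (0.00 log units; within the scatter) and a 1.0-fold lower number from compound 2 to compound 3 (0.01 log units; within the scatter). None of them left the scatter, so for compound 4 no step beyond the scatter is expected in this assay, in either direction. Compound 4 is therefore estimated at 63000 nM in this assay, with a range of 35000 nM to 115000 nM. The expected step is a 1.0-fold lower number from compound 3 to compound 4 (0.00 log units; within the scatter).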

Compound 4, half-maximal cytotoxic concentration: 40500 nM
For compound 4 the middle estimate is 1.6-fold (0.19 log units) above the measured one; measured number inside the range.
By their numbers in this assay, from the lowest: compounds 4, 1, 3 and 2 (each within the scatter of the next).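

Three fluorines on the benzyl arm, as 2,3,6-trifluorophenyl, stay within the scatter of every earlier pattern in this assay (a 1.6-fold lower number from compound 3 to compound 4 (0.19 log units; within the scatter)), and the same holds against the other two compounds (a 1.6-fold lower number from compound 2 to compound 4 (0.21 log units; within the scatter); a 1.6-fold lower number from compound 1 to compound 4 (0.19 log units; within the scatter)). These are the largest steps in the set so far, yet none establishes an effect of fluorine count or placement at this position. No supporting measurement bears on these numbers. Still open, from the compounds shown here alone, is whether an amine or a carboxylic acid on this ring, or an unsubstituted phenyl, would leave the scatter.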